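A few compounds are considered here, and "the series" means these few. Any claim that something is new, unique, unknown or untested is made for them only; others in the source may bear on it.

Measured compounds:
compound 1, `Cc1nc(N(C)C)nc(N[C@@H]2C[C@H](CO)[C@@H](O)[C@H]2O)c1-c1nc2ccccc2s1`: 18000 nM
compound 2, `CCc1nc(N(C)C)nc(N[C@@H]2C[C@H](CO)[C@@H](O)[C@H]2O)c1-c1nc2ccccc2s1`: > 25000 nM
compound 3, `CCOCCNc1nc(C)c(-c2nc3ccccc3s2)c(N[C@@H]2C[C@H](CO)[C@@H](O)[C@H]2O)n1`: 18000 nM

In an ADME assay on cells (Homo sapiens) for cytotoxicity, read by polymerase chain reaction, with a stated time of 3 days (on this read-out lower numbers stand for higher toxicity in this test and higher numbers for lower toxicity in this test), compound 1 gives 18000 nM. Compound 2 gives > 25000 nM in this assay, and that is a limit of the assay rather than a number (the limit of > 25000 nM in this assay, at which 1 of the 3 values shown sits). Compound 1 and compound 2 differ by one change, (methyl in place of hydrogen on a saturated chain carbon bound to an aromatic carbon), and the step it made is an at least 1.3-fold higher number from compound 1 to compound 2 (0.14 log units; that floor lies within the scatter). Compound 3 gives 18000 nM in this assay. Its core differs from the core of compound 1 by (2-ethoxyethyl)amino in place of dimethylamino on an aromatic carbon, and the step between them is no change at the digits printed from compound 1 to compound 3 (within the scatter).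

Compound 4, `Cc1nc(NCCOC(C)C)nc(N[C@@H]2C[C@H](CO)[C@@H](O)[C@H]2O)c1-c1nc2ccccc2s1`, has not yet been measured in this assay. It differs from compound 3 by methyl in place of hydrogen on a saturated chain carbon bound to an oxygen on a saturated carbon and a saturated chain carbon. For the measured compounds named here, this is the same kind of change as the one from compound 1 to compound 2, but it does not sit in the same surroundings: in compound 2 the entering group stands on a saturated chain carbon bound to an aromatic carbon, whereas in compound 4 it stands on a saturated chain carbon bound to an oxygen on a saturated carbon and a saturated chain carbon. Going from compound 1 to compound 2 the step was an at least 1.3-fold higher number from compound 1 to compound 2 (0.14 log units; that floor lies within the scatter), which is small. On that basis the step from compound 3 to compound 4 is expected to be a 1.2-fold higher number from compound 3 to compound 4 (0.09 log units; within the scatter), a step of similar size, resting on the value of compound 3, 18000 nM, as the starting point. Compound 4 is therefore estimated at 22000 nM in this assay, with a fair chance that only a limit is reported.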

Compound 4, half-maximal cytotoxic concentration: 8000 nM
For compound 4 the middle estimate is 2.8-fold (0.44 log units) above the measured one, outside the stated range (below it).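

In this assay, methyl in place of hydrogen on the saturated chain carbon bound to the ether oxygen gives a 2.3-fold lower number from compound 3 to compound 4 (0.35 log units; beyond the scatter), and the whole replacement of dimethylamino by (2-isopropoxyethyl)amino gives a 2.3-fold lower number from compound 1 to compound 4 (0.35 log units; beyond the scatter). Set beside the earlier case, the same kind of change does not carry over from one core to the other with the same outcome: the same change on two cores in this assay, an at least 1.3-fold higher number (0.14 log units; that floor lies within the scatter) from compound 1 to compound 2 and a 2.3-fold lower number (0.35 log units; beyond the scatter) from compound 3 to compound 4, at least 3.1-fold (0.49 log units) apart, beyond the scatter of two such steps Compound 2 gives > 25000 nM, a limit of the assay and not a number, and with only one pair on each side the comparison shows that the change did not transfer here, but it does not show how the change would behave in other surroundings or what lies behind the gap.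

The compounds shown leave open whether the lower number of compound 4 is tied to the isopropoxy end of the chain, which a (2-methoxyethyl)amino group or a longer chain such as (2-butoxyethyl)amino on the same core could help to settle. They also leave open how the ethyl group of compound 2 would read in this assay when joined to the (2-isopropoxyethyl)amino group of compound 4.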